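The source may hold more compounds than are shown below. What is called first, only, known or untested is meant among the compounds shown, and "the series" means these compounds.

Working notes on the series in an assay on isolated protein for binding affinity to Adrenergic receptor alpha-1 (Rattus norvegicus), read by radioligand binding; a lower number here means a stronger inhibitor, a higher number a weaker inhibitor. Compound 1 `COc1ccccc1N1CCN(CN2C(=O)C3CCCCN3C2=O)CC1` returns only a limit here, > 1000 nM, not a number. Compound 2 `O=C1C2CCCCN2C(=O)N1CN1CCN(c2cccc(Cl)c2)CC1` gives 135 nM. The step of an at least 7.4-fold lower number from compound 1 to compound 2 (0.86 log units; beyond the scatter) is the effect of the change (3-chlorophenyl in place of 2-methoxyphenyl on an amine nitrogen in a ring), and its size can only be read as a bound because of the limit (the limit of > 1000 nM in this assay, at which 1 of the 3 values shown sits). Among the measured compounds shown here, compound 3 `COc1ccccc1N1CCN(CCCN2C(=O)C3CCCCN3C2=O)CC1` gives 9.9 nM and is the lowest of the two numbers so far; how its core differs from the core of compound 1 is not broken down here. Compound 4 `O=C1C2CCCCN2C(=O)N1CCCN1CCN(c2cccc(Cl)c2)CC1` is not yet measured; it repeats the change on the core of compound 3, (3-chlorophenyl in place of 2-methoxyphenyl on an amine nitrogen in a ring), the same change as between compound 1 and compound 2, occurring twice among these compounds. The expected step of a 1.7-fold lower number from compound 3 to compound 4 (0.22 log units; within the scatter) rests on the step of an at least 7.4-fold lower number from compound 1 to compound 2 (0.86 log units; beyond the scatter), read cautiously since that step is a bound and the number for compound 3 is already low. Compound 4 is thus expected at about 6 nM, between 1.5 nM and 25 nM.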

Compound 4, inhibition constant: 17.9 nM
Estimate against measurement, compound 4: 3.0-fold (0.47 log units) below, within the range that was stated.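

In this assay, the change to 3-chlorophenyl in place of 2-methoxyphenyl does not carry over with one size from one core to the other, and the two steps differ beyond their scatter: the same change on two cores in this assay, an at least 7.4-fold lower number (0.86 log units; beyond the scatter) from compound 1 to compound 2 and a 1.8-fold higher number (0.26 log units; within the scatter) from compound 3 to compound 4, at least 13-fold (1.12 log units) apart, beyond the scatter of two such steps

On the core of compound 3 the change reads a 1.8-fold higher number from compound 3 to compound 4 (0.26 log units; within the scatter), so on that core no effect of the change can be told from the scatter, and two cores show neither which difference between them matters nor how the change would behave on a third core. Compound 1 gives only a limit, > 1000 nM, not a number, so the earlier step and the gap between the steps can be read only as bounds: the limit of > 1000 nM in this assay, at which 1 of the 4 values shown sits.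

Open, as far as these compounds go, is whether an unsubstituted phenyl or a pyridyl group on the same amine nitrogen would follow either step. Also open, from the compounds shown here alone, is whether a longer chain on the core of compound 3 would bring the size of the step nearer to the earlier one or leave it within the scatter.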